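Moving the bromine on the benzyl arm of an adenosine analogue

This account rests on a few compounds, and the source may have more. Where it says the series, first, only, none or still open, it means among the compounds named here.

Measured so far:
compound 1 `OC[C@H]1O[C@@H](n2cnc3c(NCc4ccccc4F)ncnc32)[C@H](O)[C@@H]1O` gives 4600 nM
compound 2 `OC[C@H]1O[C@@H](n2cnc3c(NCc4ccccc4Br)ncnc32)[C@H](O)[C@@H]1O` gives 12300 nM

Both numbers come from a functional assay on CCRF-CEM cells (Homo sapiens) for antiproliferative activity, with a stated time of 72 h; a lower number here means a stronger inhibitor, a higher number a weaker inhibitor. Compound 2 has the highest of the two numbers; its nearest neighbour is compound 1, and the step of a 2.7-fold higher number from compound 1 to compound 2 (0.43 log units; beyond the scatter) is the only one available. That step is a modest change, bromo in place of fluoro on an aromatic carbon.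

Compound 3 `OC[C@H]1O[C@@H](n2cnc3c(NCc4ccc(Br)cc4)ncnc32)[C@H](O)[C@@H]1O` keeps every atom of compound 2 but joins them differently: 4-bromophenyl in place of 2-bromophenyl on a saturated chain carbon bound to a nitrogen on an aromatic ring. Among the compounds with values here, no measured step touches this kind of change. Within the data shown here, the one step known, from compound 1 to compound 2, swaps one halogen for another at the same place and so says little about what happens when the same bromine is carried to a different place on the ring. With nothing to lean on, the most reasonable expectation is a number close to that of compound 2, with a wide margin on either side; the estimated step is a 1.0-fold lower number from compound 2 to compound 3 (0.01 log units; within the scatter). Compound 3 is therefore expected to give about 12000 nM in this assay, in a range from 4000 nM to 36000 nM.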

Compound 3, half-maximal inhibitory concentration: 20600 nM
Compound 3: middle estimate off by 1.7-fold (0.23 log units), on the low side; the range from low to high includes it.
By their numbers in this assay, from the lowest: compound 1; then compounds 2 and 3 (each within the scatter of the next).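

In this assay, carrying the bromine around the ring, from 2-bromophenyl to 4-bromophenyl, gives a 1.7-fold higher number from compound 2 to compound 3 (0.22 log units; within the scatter), so within this pair the new place for the bromine cannot be told apart from the old one. Within the data shown here, the earlier compounds offered only a swap of one halogen for another at a single place, and this pair adds the first reading on where the halogen sits on the ring. Compound 1, with its 2-fluorophenyl group, also remains clearly separated from the new compound, with a 4.5-fold higher number from compound 1 to compound 3 (0.65 log units; beyond the scatter), while nothing shown explains any of these numbers.

From the compounds shown here alone, it remains open whether a fluorine carried to the place the bromine holds in compound 3 would leave the number as unchanged as it does for bromine, since the halogen and its place have so far been varied only for bromine. Going by these compounds, how a chlorine or a methoxy group on the same ring would compare with the fluorine of compound 1 and the bromine of compound 2 is also open.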